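Ethyl ester to carboxy step at the assay limit

A few compounds are considered here, and "the series" means these few. Any claim that something is new, unique, unknown or untested is made for them only; others in the source may bear on it.

Measured in a functional assay on MCF7 cells (Homo sapiens) for cytotoxicity, read by MTT assay; on this read-out lower numbers stand for stronger inhibition and higher numbers for weaker inhibition:
- compound 1 `COc1ccc(-c2oc3c(CC=C(C)C)c(OCCOC(=O)CCC(=O)O)cc(O)c3c(=O)c2OCCOC(=O)CCC(=O)O)cc1` gives > 100000 nM (a limit)
- compound 2 `COc1ccc(-c2oc3c(CC=C(C)C)c(OC(C(=O)O)C(=O)O)cc(O)c3c(=O)c2OC(C(=O)O)C(=O)O)cc1` gives > 100000 nM (a limit)
- compound 3 `CCOC(=O)C(C)Oc1cc(O)c2c(=O)c(O)c(-c3ccc(OC)cc3)oc2c1CC=C(C)C` gives > 100000 nM (a limit)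

Compound 3 stands at > 100000 nM, which is a limit and not a number. It shares that position with the rest of the series, so no numeric reading exists yet: the limit of > 100000 nM in this assay, at which 3 of the 3 values shown sit.

Compound 4 `COc1ccc(-c2oc3c(CC=C(C)C)c(OC(C)C(=O)O)cc(O)c3c(=O)c2O)cc1` differs from compound 3 at one place: hydrogen in place of ethyl on an oxygen next to a carbonyl group. Hydrogen takes the place of ethyl on an oxygen next to a carbonyl group, turning 1-(ethoxycarbonyl)ethyl into 1-carboxyethyl. Among the compounds with values here, no measured pair isolates this change. Compound 1 and compound 2 already carry carboxy groups, and both sit at the same limit.

In this assay, no shift beyond the scatter is expected for the estimated step of a number no higher from compound 3 to compound 4 (the limit leaves the size open). The expectation rests on compound 3 , whose > 100000 nM is a limit. Compound 4 is estimated at 100000 nM, with an expected range from 40000 nM to 200000 nM.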

Compound 4, half-maximal inhibitory concentration: > 100000 nM
Compound 4: only a limit was reported; the forecaster's own chance of this, stated with the estimate: 85%; the middle value sits exactly at the limit.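

No step can be read from compound 3 to compound 4 in this assay, as both values are limits: the limit of > 100000 nM in this assay, at which 4 of the 4 values shown sit.

What hydrogen in place of ethyl on an oxygen next to a carbonyl group does in this assay stays open in the compounds shown, none of which carries a numeric value.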